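Phenyl-capped to cyclohexyl-capped chain on the shared core

This account rests on a few compounds, and the source may have more. Where it says the series, first, only, none or still open, it means among the compounds named here.

Working notes on a set of four phosphonate amides sharing one core. Compound 1 `C[C@](N)(COP(=O)(O)O)C(=O)Nc1ccc(OCCc2cccc3ccccc23)cc1` gives "not determined" (no result reported) in an assay on isolated protein for displacement of a labelled ligand from sphingosine 1-phosphate receptor 5 (Homo sapiens) (on this read-out higher numbers stand for weaker inhibition and lower numbers for stronger inhibition), and compound 3 `COc1ccc(CCCCOc2ccc(NC(=O)[C@@](C)(N)COP(=O)(O)O)cc2)cc1` likewise gives "not determined" (no result reported); for both the read-out is absent, so compound 3 stands nowhere on the measured scale. Going by the values given here, the only number comes from compound 2 `C[C@](N)(COP(=O)(O)O)C(=O)Nc1ccc(OCCCCCc2ccccc2)cc1`, which gives 2.9 nM in this assay. Compound 4 `C[C@](N)(COP(=O)(O)O)C(=O)Nc1ccc(OCCCCC2CCCCC2)cc1` remains to be measured. Compound 4 differs from compound 3 in one place: cyclohexyl in place of 4-methoxyphenyl on a saturated chain carbon, four bonds along the chain from an oxygen on an aromatic ring. Among the compounds with values here, no measured step is available for this pair, and with compound 3 lacking a number the size of the step in this assay cannot be anchored; the expectation is a step of no more than the usual scatter in either direction, with no firm direction assigned. For compound 4 the value in this assay is estimated at 5 nM, with a plausible range from 1 nM to 30 nM, resting on compound 2 because 2.9 nM is the only anchor in the series.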

Compound 4, half-maximal inhibitory concentration: 26.2 nM
Compound 4: the middle estimate sits 5.2-fold (0.72 log units) below what was measured; measured number inside the range.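

In this assay the series gains its first readable step at this position (a 9.0-fold higher number from compound 2 to compound 4 (0.96 log units; beyond the scatter)), with cyclohexyl in place of benzyl on a saturated chain carbon, four bonds along the chain from an oxygen on an aromatic ring. This step lies beyond the usual scatter, so the group at the end of the chain affects the read-out, and the saturated ring in compound 4 still leaves a value on the measured scale. No evidence bearing on the origin of this step is available.

The step from compound 3 to compound 4 cannot be read, and the effect of the 4-methoxyphenyl group therefore stays unresolved. Also open, going by these compounds, is how a cyclopentyl group, or a longer chain ending in cyclohexyl, would read in this assay.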